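Halogen Swap on the Urea Phenyl Ring

The source may hold more compounds than are shown below. What is called first, only, known or untested is meant among the compounds shown, and "the series" means these compounds.

Going by the values given here, in a functional assay on MDA-MB-231 cells (Homo sapiens) for cytotoxicity, read by MTT assay, with a stated time of 72 h (a higher number here means a weaker inhibitor, a lower number a stronger inhibitor), compound 2 `CN(C)CCNc1nc(-c2ccc(NC(=O)Nc3ccccc3F)cc2)nc2ccsc12` gives 600 nM, the lower of the two numbers measured so far, while compound 1 `CN(C)CCNc1nc(-c2ccc(NC(=O)Nc3ccccc3)cc2)nc2ccsc12` gives 1310 nM. Compound 3 `CN(C)CCNc1nc(-c2ccc(NC(=O)Nc3ccc(Cl)cc3)cc2)nc2ccsc12` carries 4-chlorophenyl in place of 2-fluorophenyl on an amide-type nitrogen. Among the compounds with values here, the one measured step that bears on this change is a 2.2-fold lower number from compound 1 to compound 2 (0.34 log units; beyond the scatter), a modest gain from adding a halogen to that phenyl ring. Exchanging the halogen and its place is therefore expected to move the number little, a step of a 1.1-fold lower number from compound 2 to compound 3 (0.04 log units; within the scatter) being expected. Compound 3 is estimated at 550 nM, with a range from 200 nM to 1500 nM.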

Compound 3, half-maximal inhibitory concentration: 310 nM
Beside the measured number, compound 3's estimate is 1.8-fold (0.25 log units) above it; measured number inside the range.
By their numbers in this assay, from the lowest: compounds 3 and 2 (each within the scatter of the next); then compound 1.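

In this assay, 4-chlorophenyl in place of 2-fluorophenyl on the amide-type nitrogen gives a 1.9-fold lower number from compound 2 to compound 3 (0.29 log units; within the scatter), so the two halogen-bearing rings cannot be told apart here. Against the unsubstituted phenyl, chloro in place of hydrogen gives a 4.2-fold lower number from compound 1 to compound 3 (0.63 log units; beyond the scatter), so a second halogen also stands beyond the scatter from compound 1. No measurement at hand accounts for these steps.

Fluoro and chloro each appear at a single place on the ring, which leaves the effect of the halogen and that of its place unseparated. Going by these compounds, how a methoxy group, an amine or a carboxylic acid on that ring would read remains open.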